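Cyano for Bromo: Expected Cytotoxicity of Compound 3

The source may hold more compounds than are shown below. What is called first, only, known or untested is meant among the compounds shown, and "the series" means these compounds.

Compound 2, `Cc1cc(S(N)(=O)=O)ccc1NC(=O)COc1ccc2ccccc2c1C(=O)c1cc(Cl)cc(Br)c1`, gives 36600 nM in an ADME assay on C8166 cells (Homo sapiens) for cytotoxicity, read by colorimetric assay and MTT assay; on this read-out higher numbers stand for lower toxicity in this test and lower numbers for higher toxicity in this test. Going by the values given here, of the two numbers measured so far, that of compound 2 is the larger, but the gap to compound 1, `Cc1ccc(C(=O)c2c(OCC(=O)Nc3ccc(S(N)(=O)=O)cc3C)ccc3ccccc23)cc1C`, which gives 33000 nM, is within the scatter, so the two are not distinguishable here. Among the compounds with values here, the single measured step, a 1.1-fold higher number from compound 1 to compound 2 (0.04 log units; within the scatter), exchanges the whole aryl group on the carbonyl carbon and leaves the read-out essentially where it was. Compound 3, `Cc1cc(S(N)(=O)=O)ccc1NC(=O)COc1ccc2ccccc2c1C(=O)c1cc(Cl)cc(C#N)c1`, has not yet been measured; it differs from compound 2 by cyano in place of bromo on an aromatic carbon. Because a 1.1-fold higher number from compound 1 to compound 2 (0.04 log units; within the scatter) already reshaped this same ring without moving the number beyond the scatter, a step within the scatter, in no particular direction, is expected for a 1.0-fold lower number from compound 2 to compound 3 (0.01 log units; within the scatter). For compound 3 the expected value in this assay is therefore 36000 nM, within a range from 18000 nM to 72000 nM.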

Compound 3, half-maximal cytotoxic concentration: 49400 nM
For compound 3 the middle estimate is 1.4-fold (0.14 log units) below the measured one; the range from low to high includes it.
By their numbers in this assay, from the lowest: compounds 1, 2 and 3 (each within the scatter of the next).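

Exchanging bromo for cyano on this aromatic carbon adds a triple bond and a hydrogen-bond acceptor, yet in this assay the result is a 1.3-fold higher number from compound 2 to compound 3 (0.13 log units; within the scatter) and the two compounds cannot be told apart. Going by these compounds alone, the earlier compounds showed only that one whole aryl group could replace another; this result shows that a single group on that ring can also be exchanged without a difference beyond the scatter. The comparison across the full aryl exchange agrees, with a 1.5-fold higher number from compound 1 to compound 3 (0.18 log units; within the scatter) for 3-chloro-5-cyanophenyl in place of 3,4-dimethylphenyl, and no supporting measurement is available to explain either result.

The compounds shown leave open whether an amine or a carboxylic acid at this position would move the number beyond the scatter. They also leave open whether a change elsewhere on the shared core would do so.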